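The source may report more compounds than this note shows. Statements on the series, on what has been measured and on what is new or still open speak of the compounds shown alone.

Of the compounds shown here, two built on one shared core have so far been measured in an assay on CHO cells for agonist activity at Free fatty acid receptor 1 (Homo sapiens), read by FLIPR; on this read-out higher numbers stand for an effect only at larger amounts of compound and lower numbers for an effect already at smaller amounts. Compound 1, with the structure `Cc1cc(OCc2sc(-c3ccccc3)nc2C)ccc1OCC(=O)O`, yields only a limit: in this assay compound 1 gives > 10000 nM, which is a limit of the assay and not a number. That reading for compound 1 is the limit of > 10000 nM in this assay, at which 1 of the 2 values shown sits. Compound 2, with the structure `Cc1nc(-c2ccc(C(F)(F)F)cc2)sc1COc1ccc(OCC(=O)O)c(F)c1`, yields a number: in this assay compound 2 gives 149 nM. Going by the values given here, of the two values shown, compound 2 therefore holds the only actual number, and nothing more can be said about how far apart the two compounds lie.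

Compound 3, with the structure `Cc1ccc(-c2nc(C)c(COc3ccc(OCC(=O)O)c(F)c3)s2)cc1`, has not yet been measured. It differs from compound 2 in one place: methyl in place of trifluoromethyl on an aromatic carbon. Among the compounds with values here, no measured pair shows this exchange, so its size is an expectation rather than a known step. The expected step from compound 2 to compound 3 is a 2.3-fold higher number from compound 2 to compound 3 (0.37 log units; beyond the scatter), a modest weakening that may still lie within the usual scatter. For compound 3 the estimate in this assay is 350 nM, with a likely range from 110 nM to 1200 nM.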

Compound 3, half-maximal effective concentration: 156 nM
Estimate against measurement, compound 3: 2.2-fold (0.35 log units) above; the range from low to high includes it.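

In this assay, going from 4-(trifluoromethyl)phenyl to 4-methylphenyl gives a 1.0-fold higher number from compound 2 to compound 3 (0.02 log units; within the scatter), so the two compounds cannot be told apart on this read-out. At this place on a six-membered aromatic ring, a group of 4 heavy atoms, three of them fluorine, and a group of 1 heavy atom therefore read alike, and fluorine is not needed there to keep a measurable number in this pair. Going by these compounds alone, this is the first direct reading of a single change on the shared core, but the measured values offer no explanation of why the two groups match.

The compounds shown leave open whether other groups at the same place, such as a chlorine atom, a methoxy group, a nitrile or an amine, would also read alike, and whether a longer chain such as ethyl or butyl would be accepted. Compound 1 has no group at this place but also differs from compound 2 elsewhere, so the effect of removing the group altogether cannot be read from it.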